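The source may hold more compounds than are shown below. What is called first, only, known or untested is meant among the compounds shown, and "the series" means these compounds.

Measured in a physicochemical assay for solubility, measured as kinetic solubility; a higher number here means a more soluble compound, a lower number a less soluble compound:
- compound 1 `O=C(NCc1ccncc1)C1CCN(C(=O)c2cc3ccccc3n2Cc2ccc(Cl)cc2)CC1`: 31000 nM
- compound 2 `CC(NC(=O)C1CCN(C(=O)c2cc3ccccc3n2Cc2ccc(Cl)cc2)CC1)c1ccncc1`: 31000 nM
- compound 3 `O=C(NCCn1ccnc1)C1CCN(C(=O)c2cc3ccccc3n2Cc2ccc(Cl)cc2)CC1`: 31000 nM

Compound 1 stands level with compound 2 and compound 3 at the digits available, so it offers no high or low reference point within the set.

The step under consideration leads to compound 4 `CN(C)C(=O)C1CCN(C(=O)c2cc3ccccc3n2Cc2ccc(Cl)cc2)CC1`, which has not yet been measured. The structural change is dimethylamino in place of ((pyridin-4-yl)methyl)amino on a carbonyl carbon. In words, this is dimethylamino in place of ((pyridin-4-yl)methyl)amino on a carbonyl carbon. The same difference, cut one bond further out, reads ((pyridin-4-yl)methyl)carbamoyl to dimethylcarbamoyl.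

Three measured steps alter the group on that carbonyl carbon: no change at the digits printed from compound 1 to compound 2 (within the scatter), no change at the digits printed from compound 1 to compound 3 (within the scatter) and no change at the digits printed from compound 2 to compound 3 (within the scatter). All three stay within the scatter. Each of the measured compounds still carries an aromatic ring in that group, so these steps bear on the change only in part. No measured case shows the group without a ring.

No step beyond the scatter is therefore expected in this assay, and no direction can be assigned, although the uncertainty is wider than for the measured steps. The expected step is no change at the digits printed from compound 1 to compound 4 (within the scatter). For compound 4 the estimated value is 31000 nM, with an expected range from 14000 nM to 45000 nM.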

Compound 4, solubility: 62000 nM
Compound 4: the middle estimate sits 2.0-fold (0.30 log units) below what was measured, and the stated range ends below it.
By their numbers in this assay, from the lowest: compounds 1, 2, 3 and 4 (each within the scatter of the next).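

In this assay compound 4 is the only compound shown with no ring and no hydrogen-bond donor in the group on the carbonyl carbon, and the step reads a 2.0-fold higher number from compound 1 to compound 4 (0.30 log units; within the scatter) with dimethylamino in place of ((pyridin-4-yl)methyl)amino. The other two comparisons read alike, with a 2.0-fold higher number from compound 3 to compound 4 (0.30 log units; within the scatter) for dimethylamino in place of (2-(1H-imidazol-1-yl)ethyl)amino and a 2.0-fold higher number from compound 2 to compound 4 (0.30 log units; within the scatter) for dimethylamino in place of (1-(pyridin-4-yl)ethyl)amino, so losing the ring and going from 8 heavy atoms to 3 in this group gives no step beyond the scatter in these pairs. No measurement at hand offers a reason for this reading.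

From the compounds shown here alone, whether a carboxylic acid, a morpholine or a longer chain ending in an amine on the carbonyl carbon would give a step beyond the scatter stays open. Also open, going by these compounds, is how this assay responds to changes elsewhere, since the core of compound 1 stays the same in all four compounds.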